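The source may report more compounds than this note shows. Statements on the series, on what has been measured and on what is new or still open speak of the compounds shown alone.

Compound 2, with the structure `COc1ccc(C(C)N(Cc2ccc(C(C)(C)C)cc2)Cc2cc3cc(C)ccc3[nH]c2=O)cc1`, was tested in a toxicity assay on MDCK cells (Canis lupus familiaris) for cytotoxicity, read by crystal violet staining, with a stated time of 48 h; a higher number here means that more compound is tolerated, a lower number that less compound is tolerated. In this assay compound 2 gives only a limit, > 5000 nM, and not a measured number. Going by the values given here, the one companion value comes from compound 1, whose structure is `CCc1ccc2[nH]c(=O)c(CN(Cc3ccc(OCOC)cc3)Cc3ccc(C(C)(C)C)cc3)cc2c1`. In this assay compound 1 likewise reaches only a limit, > 10000 nM. Both readings are thus limits: the limit of > 10000 nM in this assay, at which 1 of the 2 values shown sits, and the limit of > 5000 nM in this assay, at which 1 of the 2 values shown sits, mark where the two values sit, and neither gives a point to compare against.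

Compound 3 has the structure `CCc1ccc2[nH]c(=O)c(CN(Cc3ccc(C(C)(C)C)cc3)C(C)c3ccc(OC)cc3)cc2c1` and has not yet been measured in this assay. It differs from compound 2 by methyl in place of hydrogen on a saturated chain carbon bound to an aromatic carbon. Among the compounds with values here, no step between two measured compounds is recorded, so there is nothing to scale this change by. The expectation for compound 3 is that it behaves like compound 2, with a step that the limit leaves unreadable from compound 2 to compound 3 that stays within the scatter. Compound 3 is therefore estimated at 10000 nM, in a range from 3000 nM to 30000 nM, most likely again as a limit rather than a number.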

Compound 3, half-maximal cytotoxic concentration: > 5000 nM
Compound 3: a limit, no number; the forecaster's own chance of this, stated with the estimate: 80%; the middle value is on the limit's open side.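

Going by these compounds alone, compound 3 gives only a limit in this assay, like compound 1 and compound 2, and no step from compound 2 to compound 3 or from compound 1 to compound 3 can be read. The compounds shown leave open how much of each compound the cells tolerate, and whether methyl in place of hydrogen changes that at all.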